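Isopropyl for methyl on the dihydropyrimidinone core

The source may report more compounds than this note shows. Statements on the series, on what has been measured and on what is new or still open speak of the compounds shown alone.

The study covers three compounds that share one core, tested in an assay on HEK293 cells for antagonist activity at Voltage-dependent L-type calcium channel subunit alpha-1D (Rattus norvegicus), read by FLIPR; on this read-out lower numbers stand for stronger inhibition and higher numbers for weaker inhibition. Compound 1 `COC(=O)C1=C(C(C)C)NC(=O)N(C(=O)C(C)C)C1c1cccc([N+](=O)[O-])c1` reaches only the upper limit of the assay, a value of > 100000 nM that is a limit and not a number. Among the compounds with values here, compound 2 `COC(=O)C1=C(C)NC(=O)N(C(=O)OC(C)C)C1c1cccc([N+](=O)[O-])c1` is the single compound with a measured number, giving 4600 nM in this assay, and thus stands as the only quantified point among the values shown. Compound 1 and compound 2 differ in more than one place, so their values are simply set side by side without a step between them.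

Compound 3 `COC(=O)C1=C(C(C)C)NC(=O)N(C(=O)OC(C)C)C1c1cccc([N+](=O)[O-])c1` is not yet measured. It differs from compound 2 by isopropyl in place of methyl on a double-bonded ring carbon, placing the isopropyl that compound 1 also carries on that carbon. Since compound 1, which has that isopropyl, sits at the assay limit (the limit of > 100000 nM in this assay, at which 1 of the 2 values shown sits), the expectation for compound 3 leans toward weaker inhibition, with a real chance of another limit. Compound 3 is estimated at 30000 nM, within a range of 6000 nM to 150000 nM. The step this estimate implies, a 6.5-fold higher number from compound 2 to compound 3 (0.81 log units; beyond the scatter), is expected to lie beyond the scatter toward weaker inhibition.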

Compound 3, half-maximal inhibitory concentration: 10100 nM
Beside the measured number, compound 3's estimate is 3.0-fold (0.47 log units) above it; low and high end bracket the measured number.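

In this assay, isopropyl in place of methyl on the double-bonded ring carbon now has a measured size, a 2.2-fold higher number from compound 2 to compound 3 (0.34 log units; beyond the scatter), so the isopropyl at this position costs some inhibition but leaves a number that can still be read. Compound 3 carries the same isopropyl as compound 1, and swapping isopropyl for isopropoxy on the carbonyl carbon gives an at least 9.9-fold lower number from compound 1 to compound 3 (0.99 log units; beyond the scatter), which shows that the isopropyl alone does not put a compound at the limit and that the group on the carbonyl carbon also matters in this pair. Compound 1 is still the only compound whose value is a limit and not a number: the limit of > 100000 nM in this assay, at which 1 of the 3 values shown sits.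

The compounds shown leave open how this ring carbon responds to anything other than methyl and isopropyl, such as an ethyl group, a longer chain or a chain ending in an amine. They also leave open whether the same step would appear with a group other than isopropoxycarbonyl on the ring nitrogen, such as a methoxycarbonyl group.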